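Replacing a fluorinated pyridyl with a methylated one

The compounds below may be only part of what the source reports. "The series", "measured", "known", "first", "only" and "open" are said of these compounds alone.

Compound 1 `Cc1cccc(/C(N)=N/NC(=S)N2CCN(c3ccccn3)CC2)n1` gives > 100000 nM in a functional assay on MCF7 cells (Homo sapiens) for cytotoxicity, read by MTT assay, with a stated time of 72 h (a higher number here means a weaker inhibitor, a lower number a stronger inhibitor), a limit of the assay.
Compound 2 `N/C(=N\NC(=S)N1CCN(c2ccccn2)CC1)c1ccc(F)cn1` gives 22000 nM in this assay.
Compound 3 `Cc1ccnc(/C(N)=N/NC(=S)N2CCOCC2)c1` gives > 100000 nM in this assay, a limit of the assay.

Among the compounds with values here, compound 2 holds the only numeric value among the three; the other two sit at a limit, as noted in the limit of > 100000 nM in this assay, at which 2 of the 3 values shown sit. Within the data shown here, the one measured step, from compound 1 to compound 2, is an at least 4.5-fold lower number from compound 1 to compound 2 (0.65 log units; beyond the scatter) on exchanging 6-methylpyridin-2-yl for 5-fluoropyridin-2-yl on a carbon with a double bond to nitrogen.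

Compound 4 `Cc1ccnc(/C(N)=N/NC(=S)N2CCN(c3ccccn3)CC2)c1` differs from compound 2 by 4-methylpyridin-2-yl in place of 5-fluoropyridin-2-yl on a carbon with a double bond to nitrogen. This runs roughly opposite to the measured step, which replaced a methylpyridyl with the fluoropyridyl and lowered the number. Compound 3 also carries 4-methylpyridin-2-yl, with a different amine part, and its value is a limit. A higher number is therefore expected for compound 4, and quite possibly a limit again.

The estimated step is a 3.6-fold higher number from compound 2 to compound 4 (0.56 log units; beyond the scatter). Compound 4 is expected to give about 80000 nM, in the range 25000 nM to 300000 nM.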

Compound 4, half-maximal inhibitory concentration: 12300 nM
Compound 4: middle estimate off by 6.5-fold (0.81 log units), on the high side; the measured number lies below the stated range.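

Exchanging 5-fluoropyridin-2-yl for 4-methylpyridin-2-yl on a carbon with a double bond to nitrogen gives a 1.8-fold lower number from compound 2 to compound 4 (0.25 log units; within the scatter) in this assay, so here a methylpyridyl does as well as the fluoropyridyl. Changing 6-methylpyridin-2-yl to 4-methylpyridin-2-yl gives an at least 8.1-fold lower number from compound 1 to compound 4 (0.91 log units; beyond the scatter) in the same read-out, which shows that among these compounds it is where the methyl sits, not its presence, that separates them. From the compounds shown here alone, the full size of that step stays unknown, because compound 1 rests on a limit of the assay: the limit of > 100000 nM in this assay, at which 2 of the 4 values shown sit.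

The compounds shown leave open how an unsubstituted pyridin-2-yl or a 5-chloropyridin-2-yl would compare at this place. They also leave open whether the 5-fluoro and 4-methyl groups each matter at all, or whether any group other than 6-methyl would serve equally.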